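Trifluoromethyl to methyl on the arylpiperazine of compound 3

The compounds below may be only part of what the source reports. "The series", "measured", "known", "first", "only" and "open" are said of these compounds alone.

Measured so far in an assay on HEK293 cells for inhibition of Voltage-dependent T-type calcium channel subunit alpha-1G (Homo sapiens), read by fluorescence, tested at 10 uM; on this read-out lower numbers stand for less inhibition and higher numbers for more inhibition at the one concentration tested (going by the name of the read-out):
Compound 1 `CCCc1nc(-c2ccccc2)c(CNCCN2CCN(c3ccccc3OC)CC2)o1` gives 39.7%.
Compound 2 `CCCc1nc(-c2ccccc2)c(CNCCCN2CCN(c3cccc(C(F)(F)F)c3)CC2)o1` gives 51.6%.
Compound 3 `CCCc1nc(-c2ccccc2)c(CNCCCN2CCN(c3ccccc3C(F)(F)F)CC2)o1` gives 45%.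

Compound 3 holds the second highest of these three numbers; compound 1 sits below it and compound 2 above it, each within the scatter. Compound 4 `CCCc1nc(-c2ccccc2)c(CNCCCN2CCN(c3ccccc3C)CC2)o1` differs from compound 3 by methyl in place of trifluoromethyl on an aromatic carbon. Going by the values given here, the only measured one-place step, a number 6.6 percentage points lower from compound 2 to compound 3 (within the scatter), exchanged 3-(trifluoromethyl)phenyl for 2-(trifluoromethyl)phenyl and stayed within the scatter, so it bears on the present change only loosely. Among the compounds with values here, no measured pair exchanges a trifluoromethyl for a methyl. In this assay compound 4 is therefore expected to show no step beyond the scatter, a number 2 percentage points lower from compound 3 to compound 4 (within the scatter). The estimate for compound 4 is 43%, expected to lie between 28% and 58%.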

Compound 4, a percentage reported as inhibition, at one concentration (the size of the read-out at that concentration, not a potency): 54.5%
Estimate against measurement, compound 4: 11.5 percentage points below, and the stated range covers the measured number.
By their numbers in this assay, from the lowest: compounds 1, 3, 2 and 4 (each within the scatter of the next, the first and the last beyond it).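

In this assay, the aromatic carbon ortho to a large group carries methyl in place of trifluoromethyl with a number 9.5 percentage points higher from compound 3 to compound 4 (within the scatter), so one heavy atom serves here as well as four, as far as this read-out can tell. The exchange of 3-(trifluoromethyl)phenyl for 2-methylphenyl gives a number 2.9 percentage points higher from compound 2 to compound 4 (within the scatter), which again does not separate the two aryl groups. Nothing available explains these results.

The compounds shown leave open whether an amine or a carboxylic acid on this carbon would produce a step beyond the scatter. They also leave open how a methyl group would fare elsewhere on this ring.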